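Ethoxy to fluoro: next step from compound 3

The source may report more compounds than this note shows. Statements on the series, on what has been measured and on what is new or still open speak of the compounds shown alone.

Measured in a functional assay on HL-60 cells (Homo sapiens) for antiproliferative activity, read by MTT assay, with a stated time of 72 h; on this read-out higher numbers stand for weaker inhibition and lower numbers for stronger inhibition:
- Compound 1 `CCOc1ccc(-c2ncnn2-c2cc(OC)c(OC)c(OC)c2)cc1Cl`: 3 nM.
- Compound 2 `COc1cc(-c2ncnn2-c2ccc(Cl)cc2)cc(OC)c1OC`: > 10000 nM, a limit of the assay.
- Compound 3 `CCOc1ccc(-c2ncnn2-c2cc(OC)c(OC)c(OC)c2)cc1`: 20 nM.

Among the compounds with values here, of the two true numbers, compound 3 has the higher and so the weaker, with a 6.7-fold higher number from compound 1 to compound 3 (0.82 log units; beyond the scatter) separating it from its only numeric neighbour. Next to be measured is compound 4 `COc1cc(-n2ncnc2-c2ccc(F)cc2)cc(OC)c1OC`, reached from compound 3 by fluoro in place of ethoxy on an aromatic carbon.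

Within the data shown here, no measured step covers an exchange of ethoxy for fluoro, so the expectation rests on thin ground. Among the measured compounds shown here, the one measured step, a 6.7-fold higher number from compound 1 to compound 3 (0.82 log units; beyond the scatter), replaces chloro with hydrogen and is a different change, but it shows that a single substitution on an aromatic carbon can move the number beyond the scatter. The series also contains (the limit of > 10000 nM in this assay, at which 1 of the 3 values shown sits), which is a limit, so the range must stay wide on the high side.

For the measured compounds named here, a larger step than the one from compound 1 is expected. In this assay the estimated step is a 50-fold higher number from compound 3 to compound 4 (1.70 log units; beyond the scatter), toward weaker inhibition. The expected value for compound 4 is 1000 nM, with an estimated range of 150 nM to 8000 nM.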

Compound 4, half-maximal inhibitory concentration: > 10000 nM
Compound 4 ended at the assay's limit (the forecaster's own chance of this, stated with the estimate: 15%); at least 10-fold (1.00 log units) between middle value and limit.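

In this assay, within the data shown here, the ethoxy position proves far less tolerant of change than the only earlier step could show: that step was a 6.7-fold higher number from compound 1 to compound 3 (0.82 log units; beyond the scatter), whereas fluoro in place of ethoxy gives an at least 500-fold higher number from compound 3 to compound 4 (2.69 log units; beyond the scatter). Compound 4 gives > 10000 nM, which is a limit of the assay, so this step fixes only a minimum size and the full loss cannot be read. With this result, the top of the scale now holds a further compound, and the series can no longer be ranked there: the limit of > 10000 nM in this assay, at which 2 of the 4 values shown sit.

Still open, going by these compounds, is whether the oxygen link, the chain or both matter at this place, which a hydroxy, methoxy or propoxy group could help separate. On these data alone, it is also open whether an amine there would restore the number of compound 3, 20 nM.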